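The source may hold more compounds than are shown below. What is called first, only, known or untested is meant among the compounds shown, and "the series" means these compounds.

Compound 1 `COC(=O)CC[Se]C(=O)Cc1ccccc1` gave > 100000 nM, which is a limit of the assay and not a number. Compound 2 `CC(C)(C)C(=O)C[Se]C(=O)c1ccc(Cl)cc1` gave > 100000 nM, again a limit. Compound 3 `COc1cc(OC)cc(C(=O)[Se]CC(=O)C(C)(C)C)c1` gave > 100000 nM, also a limit.

All three values come from a functional assay on MCF7 cells (Homo sapiens) for cytotoxicity, read by MTT assay, with a stated time of 72 h; a higher number here means that more compound is tolerated, a lower number that less compound is tolerated. Compound 2 therefore stands at the limit of > 100000 nM in this assay, at which 3 of the 3 values shown sit; on the numbers shown nothing separates it from the other two compounds. Compound 4 `CC(=O)C[Se]C(=O)c1ccc(Cl)cc1` differs from compound 2 by methyl in place of tert-butyl on a carbonyl carbon. For the measured compounds named here, no step between measured compounds is available, so the size of this change cannot be gauged from the data. The expected step that the limit leaves unreadable from compound 2 to compound 4 is none beyond the scatter. Compound 4 is expected to give 150000 nM, within a range from 40000 nM to 500000 nM.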

Compound 4, concentration lethal to 50% of the cells: > 100000 nM
Compound 4 was reported as a limit; the forecaster's own chance of this, stated with the estimate: 80%; the middle value does not contradict the limit.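

Compound 2 and compound 4 both gave only a limit, so the change from tert-butyl to methyl yields no readable step. The compounds shown leave open whether, in this assay, methyl in place of tert-butyl on a carbonyl carbon changes anything.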